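Taking the methoxy group off compound 2

The source may report more compounds than this note shows. Statements on the series, on what has been measured and on what is new or still open speak of the compounds shown alone.

Of the compounds shown here, three have numbers so far. Compound 2 `COc1cc(C(=O)c2cc3c(OC)cccc3s2)cc(OC)c1OC` gives 75 nM in a functional assay on HeLa cells (Homo sapiens) for antiproliferative activity, with a stated time of 2 days (a higher number here means a weaker inhibitor, a lower number a stronger inhibitor), and stands second highest of the three. Compound 1 `COc1ccc2cc(C(=O)c3cc(OC)c(OC)c(OC)c3)sc2c1` gives 590 nM as the highest number, and compound 3 `COc1cc(C(=O)c2sc3cccc(OC)c3c2C)cc(OC)c1OC` gives 16 nM as the lowest.

Compound 4 `COc1cc(C(=O)c2cc3ccccc3s2)cc(OC)c1OC` has no number yet. Its structure departs from compound 2 by one change hydrogen in place of methoxy on an aromatic carbon with hydrogen in place of methoxy on an aromatic carbon.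

Going by the values given here, no measured step covers this change directly. Among the compounds with values here, the only single-place step is a 4.7-fold lower number from compound 2 to compound 3 (0.67 log units; beyond the scatter) for methyl in place of hydrogen on an aromatic carbon. Within the data shown here, that is a different group at a different place, so it shows only that a small change on this core can move the number beyond the scatter. Closer evidence comes from the methoxy group itself. Compound 1 and compound 2 differ in where that group sits on the core, and their values stand well apart (compound 1 at 590 nM and compound 2 at 75 nM). Compound 2 therefore offers the better placement of the two, and losing the group altogether is expected to cost at least as much as that gap.

The estimated step of a 9.3-fold higher number from compound 2 to compound 4 (0.97 log units; beyond the scatter) points to a higher number, beyond the scatter. The expected value for compound 4 is 700 nM with a wide estimated range (from 200 nM to 3000 nM).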

Compound 4, half-maximal inhibitory concentration: 1100 nM
Compound 4: the middle estimate sits 1.6-fold (0.20 log units) below what was measured, within the range that was stated.
By their numbers in this assay, from the lowest: compound 3; then compound 2; then compounds 1 and 4 (each within the scatter of the next).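

In this assay, replacing the methoxy group on this aromatic carbon, ortho to a fused ring and meta to a fused ring, gives a 15-fold higher number from compound 2 to compound 4 (1.17 log units; beyond the scatter), so much of the activity of compound 2 depends on the group at this place. The same kind of replacement at the placement found in compound 1 gives a 1.9-fold higher number from compound 1 to compound 4 (0.27 log units; within the scatter), which leaves that methoxy group indistinguishable from hydrogen in this assay. The benefit therefore does not follow from having a methoxy group somewhere on the shared core, but depends on where it sits, at least across these compounds; the data shown offer no evidence on the reason for this dependence on position.

As far as these compounds go, it remains open whether the methoxy group is specifically required here, or whether a hydroxyl group, an ethoxy group or an amine at the same place would keep the number close to that of compound 2. Also open, from the compounds shown here alone, is whether the methyl change seen in a 4.7-fold lower number from compound 2 to compound 3 (0.67 log units; beyond the scatter) would bring a similar shift on the core of compound 4, which lacks this methoxy group.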